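A hydroxy group in place of ethylamino

This account rests on a few compounds, and the source may have more. Where it says the series, first, only, none or still open, it means among the compounds named here.

Among the two compounds measured so far, compound 2, with structure `CCNCc1ccc(-c2c3ncn(CC4(O)CCN(Cc5ccc(-c6ccco6)cc5Cl)CC4)c(=O)c3nn2C)cc1`, stands lowest: in an assay on isolated protein for inhibition of ubiquitin carboxyl-terminal hydrolase 7 (Homo sapiens), with stated times of 30 min and 2 h (on this read-out higher numbers stand for weaker inhibition and lower numbers for stronger inhibition), compound 2 gives 15.2 nM. Its nearest neighbour is compound 1, `Cn1nc2c(=O)n(CC3(O)CCN(Cc4ccc(-c5ccco5)cc4Cl)CC3)cnc2c1-c1ccc(C(=N)N)cc1`, and in this assay compound 1 gives 87.5 nM. Among the compounds with values here, the one change between them, a group of four heavy atoms in place of a group of three on an aromatic carbon, brought a 5.8-fold lower number from compound 1 to compound 2 (0.76 log units; beyond the scatter).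

Compound 3, `Cn1nc2c(=O)n(CC3(O)CCN(Cc4ccc(-c5ccco5)cc4Cl)CC3)cnc2c1-c1ccc(CO)cc1`, differs from compound 2 by hydroxy in place of ethylamino on a saturated chain carbon bound to an aromatic carbon. Within the data shown here, no measured step shows this exact exchange. Among the measured compounds shown here, the only step at hand, from compound 1 to compound 2, exchanged one nitrogen-bearing group for another and gave a modest gain; the present change removes the ethylamino group altogether and puts in a single oxygen. For the measured compounds named here, with only that step to go by, compound 3 is expected to give a somewhat higher number than compound 2, a step of a 3.3-fold higher number from compound 2 to compound 3 (0.52 log units; beyond the scatter), though the evidence is thin. The estimate for compound 3 in this assay is 50 nM, within a range from 15 nM to 200 nM.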

Compound 3, half-maximal inhibitory concentration: 42.5 nM
Beside the measured number, compound 3's estimate is 1.2-fold (0.07 log units) above it; the range from low to high includes it.
By their numbers in this assay, from the lowest: compound 2; then compound 3; then compound 1.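

In this assay, putting hydroxy in place of ethylamino on a saturated chain carbon bound to an aromatic carbon gave a 2.8-fold higher number from compound 2 to compound 3 (0.45 log units; beyond the scatter), so of these two groups ethylamino goes with the stronger inhibition, although the step is modest and the nitrogen is not needed for a number in this range. The exchange also shrinks the group, from 3 heavy atoms to 1, while the counts of hydrogen-bond donors and acceptors stay the same, so those two counts alone do not settle the number here. Nitrogen by itself does not order the series either: hydroxymethyl, which has none, shows a 2.1-fold lower number from compound 1 to compound 3 (0.31 log units; beyond the scatter) against the group with a carbon and two nitrogens, leaving the two nitrogen-bearing compounds at opposite ends of the three. Nothing measured on these compounds accounts for these differences.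

Going by these compounds, whether the size of the group or the nitrogen matters more stays open, and a primary amine or a dimethylamino group on the same chain carbon would help to separate the two. A methoxy group, a carboxylic acid or a longer chain there would show how far this position tolerates other kinds of group.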